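A few compounds are considered here, and "the series" means these few. Any claim that something is new, unique, unknown or untested is made for them only; others in the source may bear on it.

Compound 1 `COc1ccc(C(=O)c2cc(OC)c(OC)c(OC)c2)cc1NC(=O)/C=C/c1cc(OC)c(OC)c(OC)c1` gives 1500 nM in a functional assay on HeLa cells (Homo sapiens) for cytotoxicity, read by MTT assay, with a stated time of 72 h (a higher number here means a weaker inhibitor, a lower number a stronger inhibitor), the lowest of the three numbers in hand. Compound 2 `COc1ccc(C(=O)c2cc(OC)c(OC)c(OC)c2)cc1NC(=O)/C=C/c1cccc(OC(F)(F)F)c1` gives 7900 nM and compound 3 `COc1ccc(C(=O)c2cc(OC)c(OC)c(OC)c2)cc1NC(=O)/C=C/c1ccc(F)c(F)c1` gives 8100 nM; the two measured steps away from compound 1, a 5.3-fold higher number from compound 1 to compound 2 (0.72 log units; beyond the scatter) and a 5.4-fold higher number from compound 1 to compound 3 (0.73 log units; beyond the scatter), run the same way and to about the same extent, while the pair a 1.0-fold higher number from compound 2 to compound 3 (0.01 log units; within the scatter) shows no separation between compounds 2 and 3. Compound 4 `COc1ccc(C(=O)c2cc(OC)c(OC)c(OC)c2)cc1NC(=O)/C=C/c1ccc(N)cc1` differs from compound 1 in one place: 4-aminophenyl in place of 3,4,5-trimethoxyphenyl on a double-bonded chain carbon bound to a double-bonded chain carbon. Among the measured compounds shown here, both known steps swap the 3,4,5-trimethoxyphenyl on that carbon for another ring, and both give a modest loss in this assay; no measured compound carries 4-aminophenyl in this position, so the expectation rests on those two steps alone and carries a wide range. On that basis compound 4 is expected to give 6000 nM, with a range from 2000 nM to 20000 nM. The expected step is a 4.0-fold higher number from compound 1 to compound 4 (0.60 log units; beyond the scatter), a weakening beyond the scatter in the direction seen for compounds 2 and 3.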

Compound 4, half-maximal inhibitory concentration: 14700 nM
For compound 4 the middle estimate is 2.5-fold (0.39 log units) below the measured one; the range from low to high includes it.
By their numbers in this assay, from the lowest: compound 1; then compounds 2, 3 and 4 (each within the scatter of the next).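

In this assay, a third ring in place of 3,4,5-trimethoxyphenyl on this double-bonded chain carbon moves the same way as the first two (a 9.8-fold higher number from compound 1 to compound 4 (0.99 log units; beyond the scatter)), and this ring carries an amine and no methoxy or fluorine group. The three replacement compounds do not separate from one another (a 1.8-fold higher number from compound 3 to compound 4 (0.26 log units; within the scatter); a 1.9-fold higher number from compound 2 to compound 4 (0.27 log units; within the scatter)), so among the four compounds only compound 1 stands apart, and the choice among 3-(trifluoromethoxy)phenyl, 3,4-difluorophenyl and 4-aminophenyl makes no readable difference. No measurement in hand accounts for the loss at this position.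

Still open, on these data alone, is whether 3,4,5-trimethoxyphenyl must stay whole, or whether 3,5-dimethoxyphenyl or 4-methoxyphenyl would match compound 1. Also open, as far as these compounds go, is whether a hydroxyl or a carboxylic acid on this ring would move the number away from the level of compounds 2, 3 and 4.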